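The compounds below may be only part of what the source reports. "The series", "measured", "known", "first", "only" and "open" are said of these compounds alone.

In an ADME assay on MT4 cells (Homo sapiens) for cytotoxicity, read by MTT assay, with a stated time of 5 days (a higher number here means that more compound is tolerated, a lower number that less compound is tolerated), compound 1 (`Cc1cc(C)cc(S(=O)(=O)c2c(C(=O)N[C@H]3CCNC3)[nH]c3ccc(Cl)cc23)c1`), which has hydrogen on the amine nitrogen in a ring, gives 10000 nM. Compound 2 (`Cc1cc(C)cc(S(=O)(=O)c2c(C(=O)N[C@@H]3CCN(Cc4cccnc4)C3)[nH]c3ccc(Cl)cc23)c1`) gives 36500 nM. With the same atoms and bonds as compound 2, compound 3 (`Cc1cc(C)cc(S(=O)(=O)c2c(C(=O)N[C@H]3CCN(Cc4cccnc4)C3)[nH]c3ccc(Cl)cc23)c1`) gives 22800 nM. This places compound 3 in the higher pair of numbers: the substituted pair shows a 1.6-fold lower number from compound 2 to compound 3 (0.20 log units; within the scatter), while the unsubstituted amine lies further off, with a 2.3-fold higher number from compound 1 to compound 3 (0.36 log units; beyond the scatter).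

Compound 4 (`Cc1cc(C)cc(S(=O)(=O)c2c(C(=O)N[C@H]3CCN(CC(N)=O)C3)[nH]c3ccc(Cl)cc23)c1`) has carbamoyl in place of pyridin-3-yl on a saturated chain carbon bound to an amine nitrogen in a ring, (carbamoyl in place of pyridin-3-yl on a saturated chain carbon bound to an amine nitrogen in a ring). For the measured compounds named here, no measured step makes this exchange. The closest guides are the two steps that add the whole (pyridin-3-yl)methyl group, a 3.7-fold higher number from compound 1 to compound 2 (0.56 log units; beyond the scatter) and a 2.3-fold higher number from compound 1 to compound 3 (0.36 log units; beyond the scatter), and both are modest. Compound 4 keeps a substituent on that nitrogen, so no step beyond the scatter is expected in this assay. The expected change is a 1.0-fold lower number from compound 3 to compound 4 (0.02 log units; within the scatter). Compound 4 is estimated at 22000 nM, with an expected range of 10000 nM to 50000 nM.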

Compound 4, half-maximal cytotoxic concentration: 28100 nM
Compound 4: the middle estimate sits 1.3-fold (0.11 log units) below what was measured, within the range that was stated.
By their numbers in this assay, from the lowest: compound 1; then compounds 3, 4 and 2 (each within the scatter of the next).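

In this assay, pyridin-3-yl on a saturated chain carbon bound to an amine nitrogen in a ring gives way to carbamoyl, which has no ring and fewer heavy atoms, with a 1.2-fold higher number from compound 3 to compound 4 (0.09 log units; within the scatter) and so no step beyond the scatter. The comparison with the other substituted compound reads the same way, with a 1.3-fold lower number from compound 2 to compound 4 (0.11 log units; within the scatter). The result also shows that a substituent without a ring on this nitrogen gives a higher number than hydrogen, with a 2.8-fold higher number from compound 1 to compound 4 (0.45 log units; beyond the scatter), as the (pyridin-3-yl)methyl group does.

On these data alone, whether a longer chain, a carboxylic acid or a simple methyl group on this nitrogen would fall in the same range stays open, as does carbamoylmethyl in the other drawn configuration. Nothing given here explains why these substituted compounds stand so close together.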